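A few compounds are considered here, and "the series" means these few. Any claim that something is new, unique, unknown or untested is made for them only; others in the source may bear on it.

Of the compounds shown here, three sharing one core have been measured in a functional assay on Jurkat cells for inhibition of nuclear factor NF-kappa-B complex (Homo sapiens); a higher number here means a weaker inhibitor, a lower number a stronger inhibitor. Compound 1 `CCOC(=O)c1cnc(-c2ccncc2)nc1NN1C(=O)C=C(C)C1=O` gives 6000 nM. Compound 2 `CCOC(=O)c1cnc(-n2nc(C)cc2C)nc1NN1C(=O)C=C(C)C1=O` gives 10000 nM. Compound 3 `CCOC(=O)c1cnc(-c2cccc(OC)c2)nc1NN1C(=O)C=C(C)C1=O` gives 5000 nM, the lowest of the three numbers, although its separation from the others is small: the step of a 1.2-fold lower number from compound 1 to compound 3 (0.08 log units; within the scatter) and the step of a 2.0-fold lower number from compound 2 to compound 3 (0.30 log units; within the scatter) both stay within the scatter, as does the step of a 1.7-fold higher number from compound 1 to compound 2 (0.22 log units; within the scatter), so no order among the three can be claimed.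

Compound 4 `CCOC(=O)c1cnc(-c2ccc(F)cc2)nc1NN1C(=O)C=C(C)C1=O` has not yet been measured. It differs from compound 3 in one place: 4-fluorophenyl in place of 3-methoxyphenyl on an aromatic carbon. Every step measured so far is a swap of the group at this same carbon, and none of them moved the number beyond the scatter, whether the group was a pyridine, a pyrazole or a methoxyphenyl. For the measured compounds named here, the change to a fluorophenyl is of the same kind, and there is no measured step that separates it from those. On that basis compound 4 is expected to sit close to compound 3, with the step of no change at the digits printed from compound 3 to compound 4 (within the scatter) expected to be no larger than the scatter. The estimate for compound 4 in this assay is therefore 5000 nM, with a range from 2000 nM to 12000 nM.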

Compound 4, half-maximal inhibitory concentration: 700 nM
Compound 4: the middle estimate sits 7.1-fold (0.85 log units) above what was measured; measured number outside the range, below it.
By their numbers in this assay, from the lowest: compound 4; then compounds 3, 1 and 2 (each within the scatter of the next).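

The swap to 4-fluorophenyl at this carbon, between two ring nitrogen atoms, gives a 7.1-fold lower number from compound 3 to compound 4 (0.85 log units; beyond the scatter) in this assay, along with an 8.6-fold lower number from compound 1 to compound 4 (0.93 log units; beyond the scatter) and a 14-fold lower number from compound 2 to compound 4 (1.15 log units; beyond the scatter), so the group here can move the number beyond the scatter, which the pyridin-4-yl, 3,5-dimethyl-1H-pyrazol-1-yl and 3-methoxyphenyl groups never did among themselves. Compound 4 is therefore the strongest inhibitor of the four, and the contrast with compound 3 shows that a six-membered aromatic ring of carbon only is not enough on its own, since both groups carry such a ring and still stand apart. The change replaces the methoxy group with fluorine and also alters where the substituent sits on the ring, and nothing available bears on why the number falls.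

Those two differences remain tangled, and a plain phenyl, a 3-fluorophenyl or a 4-methoxyphenyl at this carbon would be needed to pull them apart. As far as these compounds go, it also remains open how far the trend extends to other para substituents on the phenyl ring, such as chlorine or a nitrile, or to an amine at this carbon.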